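A few compounds are considered here, and "the series" means these few. Any claim that something is new, unique, unknown or untested is made for them only; others in the source may bear on it.

Measured compounds:
compound 1, `CC1=NC(c2cn(S(=O)(=O)c3ccc(C)cc3)c3ccccc23)CN1`: 10000 nM
compound 2, `CCC1=NC(c2cn(S(=O)(=O)c3ccc(C)cc3)c3ccccc23)CN1`: 24000 nM

In an assay on isolated protein for inhibition of kallikrein-7 (Homo sapiens), read by fluorescence, with stated times of 10 min and 30 min (on this read-out lower numbers stand for stronger inhibition and higher numbers for weaker inhibition), compound 2 gives 24000 nM, the higher of the two numbers; its nearest neighbour is compound 1, and the step of a 2.4-fold higher number from compound 1 to compound 2 (0.38 log units; beyond the scatter) lies beyond the scatter. Compound 3, `Cc1ccc(S(=O)(=O)n2cc(C3CNC(C4CCCCC4)=N3)c3ccccc32)cc1`, has not been measured; it differs from compound 2 by cyclohexyl in place of ethyl on a carbon with a double bond to nitrogen. Among the compounds with values here, the only measured step that bears on this change is the same kind of enlargement at the same site, from compound 1 to compound 2, where a modest weakening was found with a 2.4-fold higher number from compound 1 to compound 2 (0.38 log units; beyond the scatter). A much larger group now enters, and on the strength of that single step compound 3 is expected to show a further rise in number, with considerable uncertainty about its size, estimated as a 1.9-fold higher number from compound 2 to compound 3 (0.27 log units; within the scatter). The estimate for compound 3 in this assay is therefore 45000 nM, with a range from 12000 nM to 170000 nM.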

Compound 3, half-maximal inhibitory concentration: > 100000 nM
Compound 3 gave a limit, no number; the forecaster's own chance of this, stated with the estimate: 30%; middle value at least 2.2-fold (0.34 log units) away from the limit.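

In this assay, the result for compound 3 is a limit and not a number: the limit of > 100000 nM in this assay, at which 1 of the 3 values shown sits. At the carbon with a double bond to nitrogen, cyclohexyl in place of ethyl gives an at least 4.1-fold higher number from compound 2 to compound 3 (0.61 log units; beyond the scatter), and cyclohexyl in place of methyl gives an at least 10-fold higher number from compound 1 to compound 3 (1.00 log units; beyond the scatter). Compound 1, compound 2 and compound 3 thus form a series in which the number rises each time the group at this place grows from methyl to ethyl to cyclohexyl, and none of the three goes against this.

As far as these compounds go, how far the true value of compound 3 lies beyond its limit stays unknown, so both steps are bounded on one side only. Also open, from the compounds shown here alone, is whether hydrogen, an amine or a hydroxyl group at this carbon would give a lower number than compound 1 does.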